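A few compounds are considered here, and "the series" means these few. Any claim that something is new, unique, unknown or untested is made for them only; others in the source may bear on it.

Compound 1 `Cc1ccc(NC(=O)CCN(Cc2ccc(C(=O)NO)cc2)C(=O)c2cc(C)cc(C)c2)cc1` gives 31.1 nM in an assay on Sf9 cells for inhibition of protein deacetylase HDAC6 (Homo sapiens), read by fluorescence, with stated times of 90 min and 30 min; on this read-out higher numbers stand for weaker inhibition and lower numbers for stronger inhibition.
Compound 2 `CN(C)c1ccc(C(=O)N(CCC(=O)NCc2ccc(Cl)cc2)Cc2ccc(C(=O)NO)cc2)cc1` gives 10 nM in this assay.

Within the data shown here, of the two numbers measured so far, compound 2 stands at the lower one. Compound 1 gives a higher number, and the gap between them lies beyond the usual scatter of this assay. Among the measured compounds shown here, no pair of measured compounds differs in only one place, so no single structural change has yet been tied to a step in the numbers; compound 1 and compound 2 differ from each other at two positions at once.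

Compound 3 `Cc1ccc(NC(=O)CCN(Cc2ccc(C(=O)NO)cc2)C(=O)c2ccc(N(C)C)cc2)cc1` is the next compound to be measured. It differs from compound 2 by 4-methylphenyl in place of 4-chlorobenzyl on an amide-type nitrogen. Compound 3 carries the same group on that amide-type nitrogen as compound 1, while keeping the rest of compound 2. For the measured compounds named here, since no measured step isolates this change, the expected step of a 1.6-fold higher number from compound 2 to compound 3 (0.20 log units; within the scatter) is modest, toward a somewhat higher number, though a result within the scatter of compound 2 is also plausible. Compound 3 is therefore expected to give about 16 nM in this assay, within a range from 6 nM to 45 nM.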

Compound 3, half-maximal inhibitory concentration: 19.5 nM
For compound 3 the middle estimate is 1.2-fold (0.09 log units) below the measured one, and the stated range covers the measured number.
By their numbers in this assay, from the lowest: compounds 2, 3 and 1 (each within the scatter of the next, the first and the last beyond it).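

In this assay, among these compounds, 4-methylphenyl in place of 4-chlorobenzyl on the amide-type nitrogen gives a 2.0-fold higher number from compound 2 to compound 3 (0.29 log units; within the scatter), the first reading of a single change at this position, and it shows that this exchange, which removes the chlorine and alters the heavy-atom count from 8 to 7, produces no step beyond the scatter. At the second place, 4-(dimethylamino)phenyl in place of 3,5-dimethylphenyl on the carbonyl carbon gives a 1.6-fold lower number from compound 1 to compound 3 (0.20 log units; within the scatter), so this exchange also stays within the scatter, and neither single change yet separates one group from the other on this read-out. Nothing measured beyond these numbers bears on why the values fall as they do.

The step at the amide-type nitrogen combines two differences, the group on the ring and the carbon that links the ring to the nitrogen, and a 4-chlorophenyl or a 4-methylbenzyl group would be needed to read these apart. The compounds shown also leave open how a group of a different kind would read at either place, such as a carboxylic acid or a piperidine on a longer chain at the amide-type nitrogen.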